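Benzyl for tert-butoxycarbonyl on the ring amine nitrogen

The compounds below may be only part of what the source reports. "The series", "measured", "known", "first", "only" and "open" are said of these compounds alone.

Measured so far:
compound 1, `CCCSc1nc(Cl)c2c(n1)N(Cc1ccccc1)C(C(=O)N1CCN(C)CC1)N2`, 29800 nM
compound 2, `CCCSc1nc(Cl)c2c(n1)N(Cc1ccccc1)C(C(=O)N1CCN(C(=O)OC(C)(C)C)CC1)N2`, 47100 nM

In a functional assay on PC-3 cells (Homo sapiens) for antiproliferative activity, read by MTT assay, with a stated time of 72 h (on this read-out lower numbers stand for stronger inhibition and higher numbers for weaker inhibition), compound 1 gives 29800 nM and compound 2 gives 47100 nM; the two numbers sit within the scatter of each other, as a 1.6-fold higher number from compound 1 to compound 2 (0.20 log units; within the scatter) shows. Compound 3, `CCCSc1nc(Cl)c2c(n1)N(Cc1ccccc1)C(C(=O)N1CCN(Cc3ccccc3)CC1)N2`, differs from compound 2 by benzyl in place of tert-butoxycarbonyl on an amine nitrogen in a ring. Going by the values given here, no measured step exchanges a tert-butoxycarbonyl for a benzyl; the only step available, a 1.6-fold higher number from compound 1 to compound 2 (0.20 log units; within the scatter), replaced methyl with tert-butoxycarbonyl on an amine nitrogen in a ring and stayed within the scatter. No step beyond the scatter is therefore expected in this assay. Compound 3 is estimated at 35000 nM (range 12000 nM to 100000 nM), an expected step of a 1.3-fold lower number from compound 2 to compound 3 (0.13 log units; within the scatter).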

Compound 3, half-maximal inhibitory concentration: 57300 nM
The estimate for compound 3 lay 1.6-fold (0.21 log units) below the measured number, within the range that was stated.
By their numbers in this assay, from the lowest: compounds 1, 2 and 3 (each within the scatter of the next).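

In this assay, the ring amine nitrogen now tolerates a third group, an aromatic one, with no step beyond the scatter: a 1.2-fold higher number from compound 2 to compound 3 (0.09 log units; within the scatter) and a 1.9-fold higher number from compound 1 to compound 3 (0.28 log units; within the scatter) are both small. Neither the loss of the hydrogen-bond acceptors of tert-butoxycarbonyl nor the entry of the aromatic ring of benzyl separates compound 3 from compound 2 or compound 1 on this read-out. Nothing available explains this flat result. Open, on these data alone, is whether a hydrogen on this nitrogen, or an amine or carboxylic acid carried on the benzyl ring, would give a step beyond the scatter.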